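The compounds below may be only part of what the source reports. "The series", "measured", "known", "first", "only" and "open" are said of these compounds alone.

Of the compounds shown here, three in this set have been measured in a functional assay on SMA cells (Homo sapiens) for inhibition, read by MTT assay, with a stated time of 72 h; on this read-out higher numbers stand for weaker inhibition of growth and lower numbers for stronger inhibition of growth. Compound 1, with the structure `N#C/C(=C\c1c(F)c(F)c(F)c(F)c1F)C(=O)c1c[nH]c2ccccc12`, gives 20000 nM. Compound 3, with the structure `N#C/C(=C\c1ccco1)C(=O)NCc1ccc(Cl)c(Cl)c1`, gives 38000 nM. Compound 2, with the structure `COc1ccc(CNC(=O)/C(C#N)=C/c2ccc[nH]2)cc1`, returns only a limit of the assay, > 50000 nM, so its true value is not known as a number. Where compound 2 stands is summed up by the limit of > 50000 nM in this assay, at which 1 of the 3 values shown sits; no number can be set against it.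

Compound 4, with the structure `COc1ccc(CNC(=O)/C(C#N)=C/c2cc(Br)co2)cc1`, has not yet been measured in this assay . It is related to compound 2 by one change: 4-bromofuran-2-yl in place of 1H-pyrrol-2-yl on a double-bonded chain carbon bound to a double-bonded chain carbon. The amide and the methoxybenzyl part of compound 2 are kept.

Among the compounds with values here, with no measured pair that shares this change, the step from compound 2 to compound 4 cannot be read from the data. Compound 3 carries a furanyl group on the same chain and gives a number, while compound 2 gives only a limit, but the two differ in more than one place, so this shows only what the two values show. The step of an at least 1.2-fold lower number from compound 2 to compound 4 (0.09 log units; that floor lies within the scatter) is an expectation, not a measurement. Compound 4 is estimated at 40000 nM, within a range from 15000 nM to 100000 nM, with a real chance that only a limit is reported.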

Compound 4, concentration for 50% growth inhibition: > 100000 nM
Compound 4: only a limit was reported; the forecaster's own chance of this, stated with the estimate: 40%; middle value at least 2.5-fold (0.39 log units) from the limit.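

Compound 4 returns only a limit in this assay, > 100000 nM. Compound 2 also stands at a limit, > 50000 nM. Within the data shown here, with limits on both sides, no step between compound 2 and compound 4 can be read. The compounds shown leave open whether 4-bromofuran-2-yl in place of 1H-pyrrol-2-yl changes growth inhibition at all.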